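A few compounds are considered here, and "the series" means these few. Any claim that something is new, unique, unknown or untested is made for them only; others in the source may bear on it.

Compound 1 `CCCCCCCCCCCCCCC1(C(=O)N(C)C)CO1` was examined in a functional assay on the whole organism with Rattus norvegicus as the target, in the glucose tolerance test (a higher number here means that more compound is needed for the effect, a lower number that less compound is needed), where compound 1 gives 25 mg/kg. This stands as the highest of the two numbers recorded so far. The nearest is compound 2 `CCCCCCC1(C(=O)OC)CO1`, which in this assay gives 10 mg/kg, a lower number than that of compound 1 and a gap beyond the usual scatter. Among the compounds with values here, no step between two measured compounds that differ in a single place has been recorded, and compound 2 differs from compound 1 in more than one place, so the two values show only that much.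

Compound 3 `CCCCCCCCCCCCCCC1(C(=O)OCC(O)CO)CO1` has not yet been measured in this assay. It differs from compound 1 in one place: 2,3-dihydroxypropoxy in place of dimethylamino on a carbonyl carbon. Within the data shown here, the only guide is compound 2, which also lacks a dimethylcarbamoyl group and gives 10 mg/kg, though it carries a shorter chain. Compound 3 is therefore expected to show a small step toward a lower dose, a 1.7-fold lower number from compound 1 to compound 3 (0.22 log units; within the scatter), not beyond the scatter. The estimate for compound 3 is 15 mg/kg, with a range from 5 mg/kg to 50 mg/kg.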

Compound 3, minimum effective dose: 5 mg/kg
Compound 3: the middle estimate sits 3.0-fold (0.48 log units) above what was measured; measured number inside the range.
By their numbers in this assay, from the lowest: compounds 3 and 2 (each within the scatter of the next); then compound 1.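

On the carbonyl carbon whose other neighbour is a saturated ring carbon, putting 2,3-dihydroxypropoxy in place of dimethylamino gives, in this assay, a 5.0-fold lower number from compound 1 to compound 3 (0.70 log units; beyond the scatter) and thus a step beyond the scatter. Within the data shown here, this is the first change in a single place in this set, and it shows that with the long chain and the rest of the core held the same, the dose needed depends on the group carried by this carbonyl. No measurement is at hand that would account for the step.

On these data alone, it remains open whether the step belongs to the hydroxyl groups of the 2,3-dihydroxypropoxy group or to the change from dimethylcarbamoyl to an ester as such, which a simple methoxy group or a carboxylic acid at this carbonyl, with the same long chain, could separate. As far as these compounds go, it is also open how chain length acts in this setting, since compound 2 differs from compound 3 in more than one place, and a shorter chain carrying the 2,3-dihydroxypropoxy group would be needed to read that effect alone.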